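The source may report more compounds than this note shows. Statements on the series, on what has been measured and on what is new or still open speak of the compounds shown alone.

Compound 1 `COC(=[Se])Nc1ccc2c(C)cc(=O)oc2c1`, compound 2 `CCCOC(=[Se])Nc1ccc2c(C)cc(=O)oc2c1` and compound 3 `Cc1cc(=O)oc2cc(NC(=[Se])Nc3ccccc3)ccc12` share one core and differ only in the group attached to the selenium-bearing carbon. In a functional assay on WiDr cells (Homo sapiens) for inhibition, read by sulforhodamine B assay, with a stated time of 48 h (a lower number here means a stronger inhibitor of growth, a higher number a weaker inhibitor of growth), compound 1 gives a limit rather than a number, > 100000 nM (the limit of > 100000 nM in this assay, at which 1 of the 3 values shown sits). In this assay compound 2 gives 42000 nM, and compound 3 gives 34000 nM. Measured against compound 1, the steps are an at least 2.3-fold lower number from compound 1 to compound 2 (0.37 log units; beyond the scatter) and an at least 2.9-fold lower number from compound 1 to compound 3 (0.46 log units; beyond the scatter), whereas between the two numbered compounds the step is a 1.2-fold lower number from compound 2 to compound 3 (0.09 log units; within the scatter). Compound 3 thus carries the lowest of the two numbers, though its gap to compound 2 is within the scatter, and the remaining value is a limit.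

Compound 4 `Cc1cc(=O)oc2cc(NC(=[Se])Nc3ccc(C(F)(F)F)cc3)ccc12` keeps the whole of compound 3 and adds (trifluoromethyl in place of hydrogen on an aromatic carbon). Going by the values given here, none of the measured steps touches this part of the molecule: all three alter the group on the selenium-bearing carbon, and none places a substituent on the aromatic ring of the anilino group. Among the compounds with values here, no step in these data therefore sets the size of this one, and the working expectation is a change no larger than the scatter, in either direction. For compound 4 the estimated step is a 1.4-fold lower number from compound 3 to compound 4 (0.13 log units; within the scatter). Compound 4 is accordingly expected to give about 25000 nM, within a range from 7000 nM to 90000 nM.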

Compound 4, concentration for 50% growth inhibition: 6000 nM
Beside the measured number, compound 4's estimate is 4.2-fold (0.62 log units) above it, outside the stated range (below it).
By their numbers in this assay, from the lowest: compound 4; then compounds 3 and 2 (each within the scatter of the next). At a limit, above all of these: compound 1.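

Going by these compounds alone, the anilino ring of compound 3, which none of the earlier steps touched, proves responsive to substitution: in this assay, trifluoromethyl in place of hydrogen on an aromatic carbon, para to a large group, gives a 5.7-fold lower number from compound 3 to compound 4 (0.75 log units; beyond the scatter). Within the data shown here, the earlier steps all altered the group on the selenium-bearing carbon, and the only one of them read between two actual numbers stayed within the scatter, so this is the first step between two numbered compounds that lies beyond it, and it comes from a change at a different part of the molecule. Nothing measured here speaks to what lies behind the size of this step.

As far as these compounds go, whether the step belongs to trifluoromethyl itself, or would also come with a chlorine, a methoxy, a nitrile or a carboxylic acid on the same aromatic carbon, remains open, as does what trifluoromethyl would do elsewhere on that ring. From the compounds shown here alone, it is also open whether the same substitution would carry over to a compound with a longer chain or an amine on the selenium-bearing carbon in place of the anilino group.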